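Working notes: methoxy for chloro, compound 2 to compound 3

The source may report more compounds than this note shows. Statements on the series, on what has been measured and on what is new or still open speak of the compounds shown alone.

compound 1 `Fc1ccc(-c2csc(N/N=C/c3ccccc3)n2)cc1`: 790 nM
compound 2 `Fc1ccc(-c2csc(N/N=C/c3ccc(Cl)cc3)n2)cc1`: 1320 nM

In an in vitro assay on BTI-TN-5B1-4 cells for inhibition of Amine oxidase [flavin-containing] B (Homo sapiens), read by fluorescence, with a stated time of 15 min (on this read-out lower numbers stand for stronger inhibition and higher numbers for weaker inhibition), compound 1 gives 790 nM and compound 2 gives 1320 nM. Compound 2 holds the highest of the two numbers, yet the step of a 1.7-fold higher number from compound 1 to compound 2 (0.22 log units; within the scatter) lies within the scatter, so no order is drawn. Compound 3 `COc1ccc(/C=N/Nc2nc(-c3ccc(F)cc3)cs2)cc1` differs from compound 2 by methoxy in place of chloro on an aromatic carbon. Among the measured compounds shown here, the only measured step at this place, a 1.7-fold higher number from compound 1 to compound 2 (0.22 log units; within the scatter), concerned chloro for hydrogen and stayed within the scatter; nothing measured covers methoxy. The step expected in this assay is therefore none beyond the scatter, a 1.3-fold lower number from compound 2 to compound 3 (0.12 log units; within the scatter). Compound 3 is estimated at 1000 nM, range 400 nM to 2500 nM.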

Compound 3, half-maximal inhibitory concentration: 9240 nM
Estimate against measurement, compound 3: 9.2-fold (0.97 log units) below; measured number above the stated range.
By their numbers in this assay, from the lowest: compounds 1 and 2 (each within the scatter of the next); then compound 3.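

In this assay methoxy on this aromatic carbon, para to a large group, brings a 7.0-fold higher number from compound 2 to compound 3 (0.85 log units; beyond the scatter) against chloro and a 12-fold higher number from compound 1 to compound 3 (1.07 log units; beyond the scatter) against hydrogen. Hydrogen and chloro lie within the scatter of each other, so this position does respond to its substituent, and of the three groups only methoxy separates from the others. Nothing available bears on why methoxy reads this way. On these data alone, whether a hydroxyl, an amine or a longer chain such as ethoxy would read like methoxy or like chloro stays open. Also open, as far as these compounds go, is whether methoxy gives a similar step elsewhere on this ring.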